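The source may hold more compounds than are shown below. What is called first, only, known or untested is meant among the compounds shown, and "the series" means these compounds.

Compound 1 `CS(=O)(=O)c1ccc(Nc2ncc(F)c(Nc3nc4ccccc4s3)n2)cc1` is one of two compounds that give a number in a functional assay on PC-3 cells (Homo sapiens) for antiproliferative activity, read by MTT assay, with a stated time of 48 h (on this read-out higher numbers stand for weaker inhibition and lower numbers for stronger inhibition), where compound 1 gives 2830 nM. Its nearest neighbour, compound 3 `NS(=O)(=O)c1ccc(Nc2ncc(F)c(Nc3nc4ccc(Cl)cc4s3)n2)cc1`, gives 1430 nM, a gap within the usual scatter, so the two stand together. Compound 2 `Cc1cnc(Nc2ccc(S(C)(=O)=O)cc2)nc1Nc1nc2ccccc2s1` reaches only the limit > 50000 nM in this assay. For the measured compounds named here, the single measured step in one place, an at least 17-fold higher number from compound 1 to compound 2 (1.24 log units; beyond the scatter), concerns a different position and does not bear on the change to compound 4 `CS(=O)(=O)c1ccc(Nc2ncc(F)c(Nc3nc4ccc(F)cc4s3)n2)cc1`, which is fluoro in place of hydrogen on an aromatic carbon. Going by the values given here, compound 3 differs from compound 1 in more than one place, so no single step is drawn between them; its value simply sits within the scatter of compound 1. Compound 4 is therefore expected to give 1900 nM, with a range from 700 nM to 5000 nM. That amounts to an expected step of a 1.5-fold lower number from compound 1 to compound 4 (0.17 log units; within the scatter), within the scatter.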

Compound 4, half-maximal inhibitory concentration: > 50000 nM
Compound 4: no number, only a limit; the forecaster's own chance of this, stated with the estimate: 5%; at least 26-fold (1.42 log units) between middle value and limit.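

The change of hydrogen to fluoro on this aromatic carbon, in the six-membered aromatic ring of carbon only, adds a single heavy atom, yet in this assay it gives an at least 17-fold higher number from compound 1 to compound 4 (1.24 log units; beyond the scatter). This is the first step shown at this position, and it shows that the position is sensitive to even this small change. The step is a bound and not a measured size, because the value of compound 4 is a limit: the limit of > 50000 nM in this assay, at which 2 of the 4 values shown sit.

For the compounds shown here, compound 3 carries a chloro group but differs from compound 1 in more than one place, so it gives no step here. Going by these compounds, how a methoxy group or an amine on this carbon would read remains open.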